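The source may report more compounds than this note shows. Statements on the series, on what has been measured and on what is new or still open speak of the compounds shown alone.

Compound 1 `CNC(=O)CCCCCCCn1nc(-c2ccc3oc(N)nc3c2)c2c(N)ncnc21` gives 12900 nM in a functional assay on HeLa cells (Homo sapiens) for inhibition, read by MTT assay, with a stated time of 72 h; on this read-out lower numbers stand for stronger inhibition and higher numbers for weaker inhibition.
Compound 2 `Nc1ncnc2c1c(-c1cnc3[nH]ccc3c1)nn2CCCC(=O)NO` gives "not determined" (no result reported) in this assay.
Compound 3 `Nc1ncnc2c1c(-c1cnc3[nH]ccc3c1)nn2CCCCCCC(=O)NO` gives 22000 nM in this assay.

In this assay compound 1 gives 12900 nM and compound 3 gives 22000 nM; the two numbers lie within the usual scatter of each other, so neither can be ranked above the other, and compound 1 simply stands as the lower of the two numbers. For compound 2 the entry in this assay reads "not determined" (no result reported), so it offers no comparison.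

Compound 4 `Nc1nc2cc(-c3nn(CCCCC(=O)NO)c4ncnc(N)c34)ccc2o1` has not yet been measured. It keeps the core of compound 1 and differs from it in one place: hydroxycarbamoyl in place of 3-(methylcarbamoyl)propyl on a saturated chain carbon, four bonds along the chain from an aromatic nitrogen. Among the compounds with values here, no pair of measured compounds shows this change on its own, so its effect can only be guessed from the two numbers at hand, both of which are weak and close together. The step from compound 1 to compound 4 is expected to be small, at most a modest drift in either direction and most likely none beyond the scatter, a 1.1-fold lower number from compound 1 to compound 4 (0.03 log units; within the scatter). Compound 4 is therefore estimated at 12000 nM, with a range from 3500 nM to 40000 nM.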

Compound 4, half-maximal inhibitory concentration: 32200 nM
Estimate against measurement, compound 4: 2.7-fold (0.43 log units) below, within the range that was stated.
By their numbers in this assay, from the lowest: compounds 1, 3 and 4 (each within the scatter of the next, the first and the last beyond it).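

In this assay, within the data shown here, hydroxycarbamoyl in place of 3-(methylcarbamoyl)propyl on a saturated chain carbon, four bonds along the chain from an aromatic nitrogen, gives a 2.5-fold higher number from compound 1 to compound 4 (0.40 log units; beyond the scatter) and is the first change in a single place that can be read here, showing that the number does respond to what this chain carries. The same difference also reads as 6-(methylcarbamoyl)hexyl to 3-(hydroxycarbamoyl)propyl, so chain length and end group change together and the step cannot be divided between them. Nothing at hand accounts for the step.

Still open, going by these compounds, is whether a longer chain ending in hydroxycarbamoyl on the core of compound 1 would separate these two changes. A carboxylic acid or a primary amine at the end of the chain would show whether the step is tied to hydroxycarbamoyl itself.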